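A few compounds are considered here, and "the series" means these few. Any claim that something is new, unique, unknown or untested is made for them only; others in the source may bear on it.

Measured compounds:
compound 1 `COc1cc(N)c(Cl)cc1NC(=O)C1CCN(Cc2ccc(Cl)cc2)CC1`: in a functional assay on the whole organism for antagonist activity, with Mus musculus as the target (on this read-out lower numbers stand for an effect already at smaller amounts and higher numbers for an effect only at larger amounts of compound), compound 1 gives 1.2 mg/kg.
compound 2 `CCCCCCN1CCC(C(=O)Nc2cc(Cl)c(N)cc2OC)CC1`: in this assay compound 2 gives only a limit, > 10 mg/kg.
compound 3 `COc1cccc(CN2CCC(C(=O)Nc3cc(Cl)c(N)cc3OC)CC2)c1`: in this assay compound 3 gives only a limit, > 4 mg/kg.

For the measured compounds named here, compound 3 thus stands at a limit and not at a number; the other limit in the set, (the limit of > 10 mg/kg in this assay, at which 1 of the 3 values shown sits), belongs to compound 2, and the limit of > 4 mg/kg in this assay, at which 1 of the 3 values shown sits, is the one that marks compound 3. Compound 4 `CCOc1ccc(CN2CCC(C(=O)Nc3cc(Cl)c(N)cc3OC)CC2)cc1` differs from compound 3 by 4-ethoxyphenyl in place of 3-methoxyphenyl on a saturated chain carbon bound to an amine nitrogen in a ring.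

The measured steps at this position both start from compound 1: an at least 8.3-fold higher number from compound 1 to compound 2 (0.92 log units; beyond the scatter) and an at least 3.3-fold higher number from compound 1 to compound 3 (0.52 log units; beyond the scatter). The step that the two limits leave unreadable from compound 2 to compound 3 gives no readable size. Going by the values given here, both changes away from 4-chlorophenyl weakened the effect, and the ethoxy of compound 4 has no measured counterpart, so the direction of the step is uncertain; a dose near the limit of compound 3 is the most that can be inferred.

Compound 4 is expected at 4 mg/kg, with a range from 1.2 mg/kg to 15 mg/kg. The expected step is therefore a number no higher from compound 3 to compound 4 (the limit leaves the size open), small and possibly within the scatter.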

Compound 4, dose for half-maximal effect: 6.3 mg/kg
Estimate against measurement, compound 4: 1.6-fold (0.20 log units) below, and the stated range covers the measured number.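

In this assay, compound 4 gives the series its first number for a group other than 4-chlorophenyl on the saturated chain carbon bound to an amine nitrogen in a ring, and the change of chloro to ethoxy on an aromatic carbon reads as a 5.3-fold higher number from compound 1 to compound 4 (0.72 log units; beyond the scatter). The effect therefore remains measurable with 4-ethoxyphenyl, but at a larger dose than with 4-chlorophenyl, while the comparison with the pentyl group reads as an at least 1.5-fold lower number from compound 2 to compound 4 (0.20 log units; that floor lies within the scatter), so no order between those two groups is established. Compound 3 stands at a limit, and the steps that touch it cannot be read because of that limit: the limit of > 4 mg/kg in this assay, at which 1 of the 4 values shown sits.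

The groups 3-methoxyphenyl and 4-ethoxyphenyl differ in two respects at once, so the compounds shown do not separate the place of the substituent on the aromatic ring from the length of its chain, a question that 4-methoxyphenyl or 3-ethoxyphenyl would address. Going by these compounds, it also remains open whether the gap to compound 1 is specific to ethoxy or would also appear with an unsubstituted phenyl or 4-fluorophenyl.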